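Arylpiperazine hydroxypropyl ethers: T-type channel block

The source may hold more compounds than are shown below. What is called first, only, known or untested is meant among the compounds shown, and "the series" means these compounds.

Three members of the series have numbers. Compound 1 `COc1ccccc1N1CCN(C[C@@H](O)COc2ccc(Cl)cc2)CC1` gives 47.4% in an assay on HEK293 cells for inhibition of Voltage-dependent T-type calcium channel subunit alpha-1G (Homo sapiens), read by patch clamp, tested at 10 uM; a lower number here means less inhibition, a higher number more inhibition at the concentration tested (going by the name of the read-out). Compound 2 `O[C@@H](COc1ccc(Cl)cc1)CN1CCN(c2ccc(F)cc2)CC1` gives 39.7% in this assay, and compound 3 `O[C@H](COc1ccc(F)cc1)CN1CCN(c2ccc(F)cc2)CC1` gives 50% in this assay. Compound 3 reads higher than compound 2 by a margin beyond the scatter, while its gap to compound 1 is within the scatter; the difference between the cores of compound 2 and compound 3 is not broken down here.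

One change is seen twice. From compound 2 to compound 1 the change is 2-methoxyphenyl in place of 4-fluorophenyl on an amine nitrogen in a ring and the step is a number 7.7 percentage points higher from compound 2 to compound 1 (within the scatter). Compound 4 `COc1ccccc1N1CCN(C[C@H](O)COc2ccc(F)cc2)CC1` is not yet measured; it differs from compound 3 by 2-methoxyphenyl in place of 4-fluorophenyl on an amine nitrogen in a ring, the same change at the same place.

For compound 4 the step from compound 3 is expected to be a number 5 percentage points higher from compound 3 to compound 4 (within the scatter), resting on the earlier step of a number 7.7 percentage points higher from compound 2 to compound 1 (within the scatter), which was within the scatter, so a near-flat change is expected rather than a gain. Compound 4 is thus estimated at 55%, plausibly between 40% and 68%.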

Compound 4, a percentage reported as inhibition, at one concentration (the size of the read-out at that concentration, not a potency): 41%
Estimate against measurement, compound 4: 14 percentage points above; the range from low to high includes it.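

Carried to the second core, 2-methoxyphenyl in place of 4-fluorophenyl on an amine nitrogen in a ring gives a number 9 percentage points lower from compound 3 to compound 4 (within the scatter) in this assay. Set beside the first core, the change does not transfer as a fixed increment in this read-out, and the two steps cannot be treated as one shared value: the same change on two cores in this assay, a number 7.7 percentage points higher (within the scatter) from compound 2 to compound 1 and a number 9 percentage points lower (within the scatter) from compound 3 to compound 4, 16.7 percentage points apart, beyond the scatter of two such steps

Neither step alone lies beyond the scatter, so this shows a dependence on the core only through the gap between the two steps; it does not show which difference between the cores is responsible, nor what the same change would do on a third core.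

The compounds shown leave open how far this core dependence extends to other groups at the same place, such as a ring carrying an amine or a carboxylic acid. Also open, from the compounds shown here alone, is whether a longer chain in place of the hydroxypropyl link would keep or remove the difference between the two steps.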